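Nitrophenyl Replaces Bromophenyl on the Amine Nitrogen

The source may hold more compounds than are shown below. What is called first, only, known or untested is meant among the compounds shown, and "the series" means these compounds.

Measured compounds:
compound 1 `S=c1oc(-c2ccc3c(c2)OCCO3)nn1CNc1ccc(Cl)c(Cl)c1` — 6840 nM
compound 2 `S=c1oc(-c2ccc3c(c2)OCCO3)nn1CNc1cccc(Br)c1` — 10800 nM

In a functional assay, with a stated time of 6 min (on this read-out higher numbers stand for weaker inhibition and lower numbers for stronger inhibition), compound 1 gives 6840 nM and compound 2 gives 10800 nM. Compound 2 carries the larger of the two numbers, but the step of a 1.6-fold higher number from compound 1 to compound 2 (0.20 log units; within the scatter) is within the scatter, so the two compounds cannot be separated on this read-out. Compound 3 `O=[N+]([O-])c1ccccc1NCn1nc(-c2ccc3c(c2)OCCO3)oc1=S` differs from compound 2 by 2-nitrophenyl in place of 3-bromophenyl on an amine nitrogen. Going by the values given here, no measured step concerns a nitrophenyl group; the only step in hand, a 1.6-fold higher number from compound 1 to compound 2 (0.20 log units; within the scatter), concerns a change between halogenated phenyl groups and was within the scatter. With nothing pointing one way or the other, the step of a 1.1-fold lower number from compound 2 to compound 3 (0.06 log units; within the scatter) is expected to remain within the scatter, in no particular direction. Compound 3 is therefore estimated at 9500 nM, with a range from 3500 nM to 26000 nM.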

Compound 3, half-maximal inhibitory concentration: 10900 nM
The estimate for compound 3 lay 1.1-fold (0.06 log units) below the measured number, and the stated range covers the measured number.
By their numbers in this assay, from the lowest: compounds 1, 2 and 3 (each within the scatter of the next).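

In this assay the replacement of a halogenated phenyl group by 2-nitrophenyl on the amine nitrogen reads as a 1.0-fold higher number from compound 2 to compound 3 (0.00 log units; within the scatter) and as a 1.6-fold higher number from compound 1 to compound 3 (0.20 log units; within the scatter). The earlier pair covered only halogenated phenyl groups, whereas these steps show that a phenyl group carrying no halogen, with two more heavy atoms than 3-bromophenyl and with hydrogen-bond acceptors, also cannot be separated from them on this read-out. No measurement at hand bears on why the three numbers stay together.

Going by these compounds, all three compounds carry a substituted phenyl group at this position, so it remains open whether a carboxylic acid or a methoxy group on that phenyl ring would give a number beyond the scatter. On these data alone, it also remains open how a cyclohexyl group or a longer chain in place of the phenyl ring would read.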